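The source may report more compounds than this note shows. Statements on the series, on what has been measured and on what is new or still open speak of the compounds shown alone.

Working notes on a small set of analogues tested in an assay on CHO cells for displacement of a labelled ligand from adenosine receptor A1 (Homo sapiens), read by scintillation counting, with a stated time of 120 min, tested at 1 uM; a higher number here means more inhibition at the concentration tested (going by the name of the read-out), a lower number less inhibition.

Compound 1 `Cc1nc2sc(-c3ccc(F)cc3)nc2c(=O)[nH]1` gives 1% in this assay. Compound 2 `Cc1nc2sc(-c3ccc(C(F)(F)F)cc3)nc2c(=O)[nH]1` gives 1%, and compound 3 `Cc1nc2sc(-c3cccc(F)c3)nc2c(=O)[nH]1` gives 1%. All three sit together in the same low region, and no order among them can be read from these numbers.

Among the measured compounds shown here, the only step measured so far between compounds that differ in one place is no change at the digits printed from compound 1 to compound 2 (within the scatter), carrying the change (trifluoromethyl in place of fluoro on an aromatic carbon). Compound 3 shares its atoms with compound 1 but has them joined differently; the difference between the two cores is not broken down here, and the two values show nothing beyond the scatter between them.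

Compound 4 `Cc1nc2sc(-c3cccc(C(F)(F)F)c3)nc2c(=O)[nH]1` has not yet been measured in this assay. It stands to compound 3 as compound 2 stands to compound 1, through the change (trifluoromethyl in place of fluoro on an aromatic carbon). The two changes are of the same kind rather than the same: in compound 2 the entering group sits para to a large group, whereas in compound 4 it sits meta to a large group.

The expectation for the step of no change at the digits printed from compound 3 to compound 4 (within the scatter) is that it lies beside no change at the digits printed from compound 1 to compound 2 (within the scatter), since compound 1 at 1% and compound 2 at 1% showed no movement for this same kind of change. Compound 4 is accordingly estimated at 1%, with a range from -8% to 12%.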

Compound 4, a percentage reported as inhibition, at one concentration (the size of the read-out at that concentration, not a potency): 1%
Estimate against measurement, compound 4: no gap at the digits printed; the range from low to high includes it.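

In this assay the new step is no change at the digits printed from compound 3 to compound 4 (within the scatter). Set beside the earlier step, it shows trifluoromethyl in place of fluoro giving the same outcome on both cores, with no difference between the two steps: the same change on two cores in this assay, no change at the digits printed (within the scatter) from compound 1 to compound 2 and no change at the digits printed (within the scatter) from compound 3 to compound 4, 0 percentage points apart, within the scatter of two such steps This agreement is narrow, however: all four compounds sit at the same low level, with compound 4 at 1%, so neither step moves the read-out, and the pair cannot show whether the change would carry over in the same way on an analogue with clear inhibition.

The compounds shown vary only fluoro and trifluoromethyl on the six-membered aromatic ring, so it remains open whether an amine, a carboxylic acid or a longer chain at that ring would give any inhibition that stands clear of the scatter. It also remains open whether a change to the shared core itself would do so, and a percentage at one concentration gives no potency for any of these compounds.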